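A Longer Chain on Compound 2

A few compounds are considered here, and "the series" means these few. Any claim that something is new, unique, unknown or untested is made for them only; others in the source may bear on it.

Compound 1 `CCCCCCCCCCOP(=O)(O)OCCSC(=S)N1CCCC1`: > 100000 nM, a limit
Compound 2 `CCCCCCOP(=O)(O)OCCSC(=S)N1CCCC1`: > 100000 nM, a limit

These values come from an ADME assay on HEK293 cells (Homo sapiens) for inhibition, read by MTT assay, with stated times of 18 h and 4 h; on this read-out higher numbers stand for weaker inhibition and lower numbers for stronger inhibition. Compound 2 stands only at a limit, > 100000 nM, and not at a number. Compound 3 `CCCCCCCCCCCCCCCCOP(=O)(O)OCCSC(=S)N1CCCC1` differs from compound 2 by decyl in place of hydrogen on a saturated chain carbon, six bonds along the chain from an oxygen on an unsaturated carbon. Among the compounds with values here, the one measured step that bears on this change is a step that the two limits leave unreadable from compound 1 to compound 2. The evidence on it is the limit of > 100000 nM in this assay, at which 2 of the 2 values shown sit. That step offers no size or direction to carry over, so no step beyond the scatter is expected in this assay. The expected step is a number no higher from compound 2 to compound 3 (the limit leaves the size open). For compound 3 the estimate is 100000 nM, with an expected range of 30000 nM to 200000 nM.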

Compound 3, half-maximal inhibitory concentration: > 100000 nM
Compound 3: only a limit was reported; the forecaster's own chance of this, stated with the estimate: 65%; the middle value sits exactly at the limit.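

Compound 3 gives > 100000 nM, which is a limit, and no step can be read among compound 1, compound 2 and compound 3. The compounds shown leave open whether chain length has any bearing on inhibition.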